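The source may hold more compounds than are shown below. What is called first, only, known or untested is meant among the compounds shown, and "the series" means these compounds.

Compound 1 `CC1=C(C(=O)CC(C)C)C(c2ccco2)NC(=O)N1` and compound 2 `CC1=C(C(=O)OC2CCC2)C(c2ccco2)NC(=O)N1` share one core and differ only in the group on the carbonyl carbon. In an assay on membranes from HEK293 cells for displacement of a labelled ligand from adenosine receptor A2b (Homo sapiens), read by scintillation counting, with a stated time of 30 min (a higher number here means a weaker inhibitor, a lower number a stronger inhibitor), compound 1 gives 240 nM, and compound 2 gives 95.1 nM. For the measured compounds named here, that change, a 2.5-fold lower number from compound 1 to compound 2 (0.40 log units; beyond the scatter), is the only measured step so far, and it leaves compound 2 with the lowest of the two numbers, with compound 1 standing a modest distance higher.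

Compound 3 `CC1=C(C(=O)OCC2CC2)C(c2ccco2)NC(=O)N1` keeps the oxygen of compound 2 and changes only the group on that oxygen: cyclopropylmethyl in place of cyclobutyl on an oxygen next to a carbonyl group. Going by the values given here, no measured step bears directly on this change; the step from compound 1 to compound 2 swapped one kind of group for another on the carbonyl carbon, whereas here the same atoms are only rejoined into a different shape. With nothing in the measured data pointing one way or the other, a step within the scatter, a 1.1-fold higher number from compound 2 to compound 3 (0.02 log units; within the scatter), is expected. The estimate for compound 3 in this assay is therefore 100 nM, with a range from 40 nM to 250 nM.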

Compound 3, inhibition constant: 138 nM
For compound 3 the middle estimate is 1.4-fold (0.14 log units) below the measured one, and the stated range covers the measured number.
By their numbers in this assay, from the lowest: compounds 2, 3 and 1 (each within the scatter of the next, the first and the last beyond it).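

In this assay, rejoining the same atoms from cyclobutyl into cyclopropylmethyl on an oxygen next to a carbonyl group gives a 1.5-fold higher number from compound 2 to compound 3 (0.16 log units; within the scatter), so at this position the two shapes cannot be told apart. The comparison with isobutyl gives a 1.7-fold lower number from compound 1 to compound 3 (0.24 log units; within the scatter), which means that the clear separation seen between compound 1 and compound 2 does not carry over to every group attached through this oxygen, and compound 3 cannot be separated from either neighbour. No independent measurement is available to explain these numbers.

From the compounds shown here alone, the groups on this oxygen are both small carbon groups containing a strained ring, so the effect of a longer chain such as n-hexyl, an aromatic ring such as phenyl, or a chain ending in an amine remains open. Going by these compounds, it is also open how the numbers would respond if an amide nitrogen took the place of the oxygen while cyclobutyl or cyclopropylmethyl stayed attached.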